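Benzoyl for 4-methoxybenzyl on an amine nitrogen

The source may hold more compounds than are shown below. What is called first, only, known or untested is meant among the compounds shown, and "the series" means these compounds.

Compounds measured in a physicochemical assay for solubility, with a stated time of 3 days, at pH 2 (a higher number here means a more soluble compound, a lower number a less soluble compound), are these
Compound 1 (`CN1CCC(Oc2ccc(-c3nc4cc(C(N)=O)ccc4[nH]3)cc2)C1`) – "not determined" (no result reported)
Compound 2 (`CN1CCC(Oc2ccc(-c3nc4cc(C(N)=O)ccc4[nH]3)cc2)CC1`) – > 400000 nM (a limit)
Compound 3 (`COc1ccc(CN2CCCCC2CCOc2ccc(-c3nc4cc(C(N)=O)ccc4[nH]3)cc2)cc1`) – > 400000 nM (a limit)

On these data alone, compound 3 has no exact number to its name, only a limit, so its true place remains open. The series as a whole offers little more, namely the limit of > 400000 nM in this assay, at which 2 of the 3 values shown sit, and no reported result for compound 1.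

Compound 4 (`NC(=O)c1ccc2[nH]c(-c3ccc(OCCC4CCCCN4C(=O)c4ccccc4)cc3)nc2c1`) differs from compound 3 in one place (benzoyl in place of 4-methoxybenzyl on an amine nitrogen in a ring), with benzoyl in place of 4-methoxybenzyl on an amine nitrogen in a ring, next to the ring atom that bears a large group. Within the data shown here, no measured pair shows what such a change does. In compound 2 and compound 3 that nitrogen carries no carbonyl, so compound 4 would be the first of the set to carry one there.

The expectation starts from compound 3 and its limit of > 400000 nM alone. A downward step is expected in this assay, estimated an at least 2.6-fold lower number from compound 3 to compound 4 (0.42 log units; beyond the scatter) and uncertain in size. For compound 4 the expected value is 150000 nM with an estimated range of 30000 nM to 400000 nM for now.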

Compound 4, solubility: 28000 nM
Compound 4: middle estimate off by 5.4-fold (0.73 log units), on the high side; measured number outside the range, below it.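

Among these compounds, at this position, on an amine nitrogen in a ring, next to the ring atom that bears a large group, benzoyl in place of 4-methoxybenzyl gives an at least 14-fold lower number from compound 3 to compound 4 (1.15 log units; beyond the scatter) in this assay and so provides the first readable step. Among the compounds shown here, compound 4 also supplies the first exact number of the set, whereas the earlier compounds offered only a limit or no reported result. The printed step marks the smallest drop consistent with the data and not its true size, because the value for compound 3 is a limit: the limit of > 400000 nM in this assay, at which 2 of the 4 values shown sit.

On these data alone, it remains open whether the lower number goes with the carbonyl on that nitrogen or with the benzoyl group as a whole, as the change replaces one entire group with another. A plain benzyl or an acetyl on the same nitrogen would separate these two readings, and a benzoyl carrying a methoxy group would show whether that part of the leaving group plays any role in the step.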